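The compounds below may be only part of what the source reports. "The series", "measured", "known", "first", "only" and "open" are said of these compounds alone.

Of the compounds shown here, three built on one shared core have so far been measured in an assay on HEK293 cells for inhibition of Steryl-sulfatase (Homo sapiens), tested at 0.1 uM; a higher number here means a stronger effect of the compound at the concentration tested, a lower number a weaker effect. Compound 1 `CCN(Cc1ccccc1)Cc1ccc(CN2CCc3ccc(OS(N)(=O)=O)cc3C2)cc1` gives 1%. Compound 2 `CN(C)CCCN(Cc1ccccc1)c1cccc(C(=O)N2CCc3ccc(OS(N)(=O)=O)cc3C2)c1` gives 23.8%. Compound 3 `CCN(Cc1cccnc1)c1ccc(C(=O)N2CCc3ccc(OS(N)(=O)=O)cc3C2)cc1` gives 35.7%, the highest of the three numbers; its gap to compound 2 and its larger gap to compound 1 both lie beyond the usual scatter of such measurements.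

Compound 4 `CCCN(CCC)c1ccc(C(=O)N2CCc3ccc(OS(N)(=O)=O)cc3C2)cc1` has not yet been measured. It differs from compound 3 in a single place: dipropylamino in place of ethyl((pyridin-3-yl)methyl)amino on an aromatic carbon. The leaving group carries one six-membered aromatic ring with one hetero atom and two hydrogen-bond acceptors; the entering dipropylamino has no ring and one hydrogen-bond acceptor. For the measured compounds named here, no measured pair among the first three compounds shows a change of this kind, so no direct step is available to lean on, and the expectation rests on compound 3 alone.

The change from compound 3 is expected to lower the number somewhat, as a number 10.7 percentage points lower from compound 3 to compound 4 (beyond the scatter), though a result within the scatter would not be surprising. Compound 4 is therefore estimated to give 25%, with a range from 8% to 42%.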

Compound 4, a percentage reported as inhibition, at one concentration (the size of the read-out at that concentration, not a potency): 36.6%
Estimate against measurement, compound 4: 11.6 percentage points below; the measured number falls inside the stated range.
By their numbers in this assay, from the lowest: compound 1; then compound 2; then compounds 3 and 4 (each within the scatter of the next).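

The step of a number 0.9 percentage points higher from compound 3 to compound 4 (within the scatter) in this assay comes with dipropylamino in place of ethyl((pyridin-3-yl)methyl)amino, and it shows that these two groups cannot be told apart at this place, on an aromatic carbon para to a large group. The six-membered aromatic ring with its hetero atom is therefore not required to keep the number at this level, since a group with no ring and one hydrogen-bond acceptor reads the same within the scatter. No measurement at hand explains why the two groups read alike.

The compounds shown leave open whether a much smaller group at this place, such as dimethylamino or a plain amine, would hold the number. Also open, going by these compounds, is what a longer chain, such as dibutylamino, or a carboxylic acid there would do.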